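Chlorine position on the aryl ether, pyrrolidine acid series

The compounds below may be only part of what the source reports. "The series", "measured", "known", "first", "only" and "open" are said of these compounds alone.

Compound 1 `O=C(O)C[C@@H]1CCCN1c1ccc(Oc2ccccc2F)cc1` gives 6900 nM in a functional assay on cells for agonist activity at Free fatty acid receptor 1 (Mus musculus), read by FLIPR and calcium flux, with a stated time of 100 s; on this read-out lower numbers stand for an effect already at smaller amounts and higher numbers for an effect only at larger amounts of compound. Compound 2 `O=C(O)C[C@@H]1CCCN1c1ccc(Oc2cccc(Cl)c2)cc1` reaches only the assay limit of > 16000 nM; this is a limit, not a measured number. Going by the values given here, the one measured step, an at least 2.3-fold higher number from compound 1 to compound 2 (0.36 log units; beyond the scatter), therefore rests on that limit (the limit of > 16000 nM in this assay, at which 1 of the 2 values shown sits). Compound 3 `O=C(O)C[C@@H]1CCCN1c1ccc(Oc2ccc(Cl)cc2)cc1` differs from compound 2 by 4-chlorophenyl in place of 3-chlorophenyl on an oxygen on an aromatic ring. Among the compounds with values here, no measured step moves the chlorine around the ring, so the step of a number no higher from compound 2 to compound 3 (the limit leaves the size open) is expected to stay within the scatter, with no clear direction. Compound 3 is estimated at 16000 nM, between 5000 nM and 50000 nM, and a further limit is quite possible.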

Compound 3, half-maximal effective concentration: > 33000 nM
Compound 3: no number, only a limit; the forecaster's own chance of this, stated with the estimate: 50%; at least 2.0-fold (0.31 log units) between middle value and limit.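

Compound 3, with 4-chlorophenyl, also ends at a limit and not at a number: the limit of > 33000 nM in this assay, at which 1 of the 3 values shown sits. Against 2-fluorophenyl, this change gives an at least 4.7-fold higher number from compound 1 to compound 3 (0.67 log units; beyond the scatter), so a second chlorophenyl compound now stands on the higher-number side of compound 1. The step between compound 2 and compound 3 cannot be read, so 3-chlorophenyl and 4-chlorophenyl cannot be ranked against each other.

From the compounds shown here alone, whether any chlorophenyl on this oxygen gives a measurable number remains open. 2-Chlorophenyl and 4-fluorophenyl would help separate the choice of halogen from its place on the ring.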